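Swapping the Aryl Urea End in a Thiophene Sulfonamide Series

This account rests on a few compounds, and the source may have more. Where it says the series, first, only, none or still open, it means among the compounds named here.

Compound 3 `COc1ccc(NC(=O)NCCNS(=O)(=O)c2ccc(-c3ccccc3OCc3cccc(O)c3)s2)cc1` is tested in a functional assay on RS4-11 cells (Homo sapiens) for inhibition, read by CCK-8 assay, with a stated time of 48 h (a higher number here means a weaker inhibitor, a lower number a stronger inhibitor), where compound 3 gives 9400 nM. This is the highest of the three numbers seen so far. Its closest neighbour is compound 2 `O=S(=O)(NCCNC(=S)Nc1cccc(Cl)c1)c1ccc(-c2ccccc2OCc2cccc(O)c2)s1`, which in this assay gives 5800 nM; the change a 1.6-fold higher number from compound 2 to compound 3 (0.21 log units; within the scatter) stays within the scatter, so the two cannot be ordered. The furthest is compound 1 `O=[N+]([O-])c1ccc(NC(=S)NCCNS(=O)(=O)c2ccc(-c3ccccc3O[C@H]3CC[C@H](O)CC3)s2)cc1`, which gives 1500 nM, a gap beyond the scatter.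

Compound 4 `O=[N+]([O-])c1ccc(NC(=S)NCCNS(=O)(=O)c2ccc(-c3ccccc3OCc3cccc(O)c3)s2)cc1` differs from compound 3 in one place: a group of 12 heavy atoms (7 carbon, 2 nitrogen, 2 oxygen, 1 sulfur; one six-membered aromatic ring of carbon only) in place of a group of 11 heavy atoms (8 carbon, 1 nitrogen, 2 oxygen; one six-membered aromatic ring of carbon only), on an amine nitrogen. Among the measured compounds shown here, no measured step covers exactly this exchange. For the measured compounds named here, the only step at hand, from compound 2 to compound 3, replaces one aryl group by another on the same amine nitrogen and stays within the scatter. Going by the values given here, compound 1 carries a different ether and shows the lower value above, but its ether is not the one in compound 4, so no firm direction follows.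

A modest drop in number, a 2.7-fold lower number from compound 3 to compound 4 (0.43 log units; beyond the scatter), is therefore expected, and compound 4 is estimated at 3500 nM, with a range of 1200 nM to 10000 nM.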

Compound 4, half-maximal inhibitory concentration: 10100 nM
Beside the measured number, compound 4's estimate is 2.9-fold (0.46 log units) below it; the whole stated range lies below it.
By their numbers in this assay, from the lowest: compound 1; then compounds 2, 3 and 4 (each within the scatter of the next).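

With the 3-hydroxybenzyl ether held fixed, changing the aryl end gives no separable difference in this assay: there is a 1.1-fold higher number from compound 3 to compound 4 (0.03 log units; within the scatter) for the exchange at the amine nitrogen, and a 1.7-fold higher number from compound 2 to compound 4 (0.24 log units; within the scatter) for 4-nitrophenyl in place of 3-chlorophenyl on an amide-type nitrogen. The clear step comes from the other end of the molecule, where 3-hydroxybenzyl in place of 4-hydroxycyclohexyl on an oxygen on an aromatic ring gives a 6.7-fold higher number from compound 1 to compound 4 (0.83 log units; beyond the scatter) with the 4-nitrophenyl end kept. Among these compounds, then, only the ether exchange moves the number beyond the scatter, and nothing available explains this.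

On these data alone, whether an aryl end carrying an amine or a carboxylic acid would also leave the number in place remains open. So does the effect of a longer chain on the ether oxygen.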